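Bromo to fluoro: a one-atom swap on the ring

This account rests on a few compounds, and the source may have more. Where it says the series, first, only, none or still open, it means among the compounds named here.

In a functional assay on MCF7 cells (Homo sapiens) for antiproliferative activity, read by MTT assay, with a stated time of 72 h (on this read-out higher numbers stand for weaker inhibition and lower numbers for stronger inhibition), compound 1 `O=C(N/N=C/c1ccccc1)Nc1ccc(Oc2ccnc3[nH]ccc23)c(F)c1` gives 2380 nM. Among the measured compounds shown here, compound 2 `O=C(N/N=C/c1ccc(Br)cc1)Nc1ccc(Oc2ccnc3[nH]ccc23)c(F)c1` gives 930 nM, the lower of the two numbers so far, and so the stronger inhibition. Compound 3 `O=C(N/N=C/c1ccc(F)cc1)Nc1ccc(Oc2ccnc3[nH]ccc23)c(F)c1` has not yet been measured. It differs from compound 2 as follows: fluoro in place of bromo on an aromatic carbon. In plain words, this is fluoro in place of bromo on an aromatic carbon, or 4-bromophenyl to 4-fluorophenyl.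

For the measured compounds named here, only one measured step bears on this change. Bromo in place of hydrogen on an aromatic carbon gave a 2.6-fold lower number from compound 1 to compound 2 (0.41 log units; beyond the scatter). Going by the values given here, no fluoro compound has been measured yet, so this single step is only a rough guide. The working expectation is that compound 3 falls somewhere between compound 1 and compound 2 in this assay, which would give back part of that modest step. The expected change is a 1.6-fold higher number from compound 2 to compound 3 (0.21 log units; within the scatter), towards a higher number and perhaps not clearly beyond the scatter. Compound 3 is estimated at 1500 nM, with an expected range from 700 nM to 3200 nM.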

Compound 3, half-maximal inhibitory concentration: 800 nM
The estimate for compound 3 lay 1.9-fold (0.27 log units) above the measured number, within the range that was stated.
By their numbers in this assay, from the lowest: compounds 3 and 2 (each within the scatter of the next); then compound 1.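

In this assay, fluoro in place of bromo gives a 1.2-fold lower number from compound 2 to compound 3 (0.07 log units; within the scatter), so at this place on the ring the two halogens cannot be told apart. Measured against the unsubstituted ring, fluoro gives a 3.0-fold lower number from compound 1 to compound 3 (0.47 log units; beyond the scatter), which shows that the gain seen on adding bromo is not unique to bromo: both halogen-bearing compounds sit clearly below compound 1, and none of the three compounds goes against this. No other measurement accompanies these numbers, so why the two halogens match cannot be said from the data at hand.

The compounds shown leave open whether a halogen is needed at all, since a methoxy group, an amine or a carboxylic acid in this same place could either keep the gain or lose it. They also carry the halogen in only this one place on the ring, so what bromo or fluoro would do elsewhere on it remains an open question.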